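The compounds below may be only part of what the source reports. "The series", "measured", "known", "first", "only" and "open" are said of these compounds alone.

Series notes. Compound 1 `CC1=C(C(=O)OCc2ccccn2)C(c2ccc(Br)cc2)C2=C(CCCC2=O)N1` is the reference point. Among the measured compounds shown here, in a physicochemical assay for lipophilicity, measured as octanol-water partition (on this read-out lower numbers stand for lower lipophilicity and higher numbers for higher lipophilicity), compound 1 gives 2.42, the highest of the three numbers measured so far. Compound 2 `CC1=C(C(=O)OCc2cccnc2)C(c2ccc(Br)cc2)C2=C(CCCC2=O)N1` gives 2.05, and compound 3 `COc1cc(C2C(C(=O)OCc3ccccn3)=C(C)NC3=C2C(=O)CCC3)cc(OC)c1OC` gives 2.17; the gap between compound 1 and compound 3 lies within the scatter, while the gap to compound 2 lies beyond it. For the measured compounds named here, the only single-point step among the measured compounds is a number 0.37 log units lower from compound 1 to compound 2 (beyond the scatter), a swap on the ester side of the shared core.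

Compound 4 `CC1=C(C(=O)OCc2ccccn2)C(c2ccccc2)C2=C(CCCC2=O)N1` has not yet been measured. Relative to compound 1 the change is hydrogen in place of bromo on an aromatic carbon. Going by the values given here, no measured step touches this part of the molecule: the step from compound 1 to compound 2 concerns the pyridin-2-yl to pyridin-3-yl swap, and compound 3 differs from compound 1 in more than one place, so nothing among the measured numbers speaks directly to the loss of bromo. Judged from the structural change alone, a downward step is expected, a number 0.77 log units lower from compound 1 to compound 4 (beyond the scatter). For compound 4 the estimate is 1.65, within a range of 1.25 to 2.1.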

Compound 4, partition coefficient: 2.72
Compound 4: the middle estimate sits 1.07 log units below what was measured; measured number outside the range, above it.
By their numbers in this assay, from the lowest: compounds 2, 3, 1 and 4 (each within the scatter of the next, the first and the last beyond it).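

In this assay, the change from 4-bromophenyl to phenyl, on an aromatic carbon para to a large group, gives a number 0.30 log units higher from compound 1 to compound 4 (within the scatter). Among the compounds shown here, this single swap therefore leaves no separable difference between the two compounds, whereas the only earlier step, the pyridin-3-yl in place of pyridin-2-yl swap, gave a number 0.37 log units lower from compound 1 to compound 2 (beyond the scatter), beyond the scatter. No measurement on hand offers an explanation for this result.

Still open, as far as these compounds go, is whether another group at this place, such as fluoro, an amine or a carboxylic acid, would give a step beyond the scatter. For the compounds shown here, also open is whether hydrogen in place of bromo gives a similar step in the pyridin-3-yl setting of compound 2, as no measured pair shows this change there.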